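The compounds below may be only part of what the source reports. "The series", "measured", "known", "first", "only" and "open" are said of these compounds alone.

In a functional assay on HeLa cells (Homo sapiens) for cytotoxicity, read by WST assay, with a stated time of 48 h (a higher number here means a weaker inhibitor, a lower number a stronger inhibitor), three compounds built on a shared core have been measured. Compound 1 `O[C@@H](c1ccccc1)[C@H]1CO[C@H](c2ccccc2)[C@@H](C/C=C/c2ccccc2)C1` gives 6060 nM, compound 2 `Cc1ccc(/C=C/C[C@H]2C[C@@H]([C@@H](O)c3ccccc3)CO[C@@H]2c2ccccc2)cc1C` gives 10000 nM, and compound 3 `O[C@@H](c1ccccc1)[C@H]1CO[C@H](c2ccccc2)[C@@H](C/C=C/C2CCCCC2)C1` gives 6440 nM. Compound 3 thus stands within the scatter of both of the others, with a 1.1-fold higher number from compound 1 to compound 3 (0.03 log units; within the scatter) and a 1.6-fold lower number from compound 2 to compound 3 (0.19 log units; within the scatter). The compound still to be measured, compound 4 `O[C@@H](c1ccccc1)[C@H]1CO[C@H](c2ccccc2)[C@@H](C/C=C/c2cccnc2)C1`, keeps the core and changes one group: pyridin-3-yl in place of cyclohexyl on a double-bonded chain carbon bound to a double-bonded chain carbon. The change is pyridin-3-yl in place of cyclohexyl, on a double-bonded chain carbon bound to a double-bonded chain carbon.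

For the measured compounds named here, all the measured steps bear on this same place, and the remaining one, a 1.7-fold higher number from compound 1 to compound 2 (0.22 log units; within the scatter), is just as small as the two above. Aromatic and non-aromatic six-membered rings have so far given values that cannot be told apart, as the step between compound 1 and compound 3 shows. However, no measured compound carries a ring with a hetero atom here, so the data cannot speak directly to that feature. A step beyond the scatter is therefore not expected in this assay, and no direction is favoured. The expected step is a 1.1-fold higher number from compound 3 to compound 4 (0.04 log units; within the scatter). The estimated value for compound 4 is 7000 nM, with an expected range from 3500 nM to 14000 nM.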

Compound 4, half-maximal inhibitory concentration: > 100000 nM
Compound 4 ended at the assay's limit (the forecaster's own chance of this, stated with the estimate: 20%); at least 14-fold (1.15 log units) between middle value and limit.
By their numbers in this assay, from the lowest: compounds 1, 3 and 2 (each within the scatter of the next). At a limit, above all of these: compound 4.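

In this assay compound 4 ends at a limit of the assay and not at a number: the limit of > 100000 nM in this assay, at which 1 of the 4 values shown sits.

Even so, the limit yields steps beyond the scatter, with an at least 15-fold higher number from compound 3 to compound 4 (1.19 log units; beyond the scatter) and an at least 16-fold higher number from compound 1 to compound 4 (1.21 log units; beyond the scatter) as well as an at least 10-fold higher number from compound 2 to compound 4 (1.00 log units; beyond the scatter) at this place on a double-bonded chain carbon bound to a double-bonded chain carbon. The earlier compounds showed only that three carbon-only rings, aromatic or not, could not be told apart here, whereas this result shows that the position is not indifferent to the ring it carries: pyridin-3-yl has the same count of heavy atoms as cyclohexyl, yet it brings one ring nitrogen and one hydrogen-bond acceptor and stands apart from all three, with no compound shown going against this.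

The compounds shown leave open whether the ring nitrogen as such or its place in the ring goes with this loss, which pyridin-2-yl or pyridin-4-yl would address. They also leave open whether a phenyl ring carrying a hydroxyl or a methoxy group, or a piperidine ring, would stay with the carbon-only rings or go with compound 4.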